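This account rests on a few compounds, and the source may have more. Where it says the series, first, only, none or still open, it means among the compounds named here.

Compound 3 `CCc1cc(CN2CC(C(=O)O)C2)sc1-c1ncc(-c2ccc(OC(C)C)cc2)s1` stands highest of the two numbers in a functional assay on the whole organism (spleen, spleen, strain LEW) for inhibition, with Rattus norvegicus as the target, with a stated time of 4 days, at a dose of 1 mg/kg by the oral route (a higher number here means more inhibition at the dose given (going by the name of the read-out), a lower number less inhibition), where compound 3 gives 52%. Its nearest neighbour is compound 2 `CCc1cc(CN2CC(C(=O)O)C2)sc1-c1ncc(-c2ccc(Oc3ccccc3)cc2)s1`, which in this assay gives 42%; the step of a number 10 percentage points higher from compound 2 to compound 3 (within the scatter) lies within the scatter. Compound 1 `CCc1cc(CN2CC(C(=O)O)C2)sc1-c1cc(-c2ccc(Oc3ccccc3)cc2)no1` is reported in this assay as "not active" (no number reported), so no number exists for it.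

Compound 4 `CCc1cc(CN2CC(C(=O)O)C2)sc1-c1ncc(-c2ccc(OC(C)C)c(Cl)c2)s1` differs from compound 3 by chloro in place of hydrogen on an aromatic carbon. Among the compounds with values here, no measured step adds a chloro group, so none bears directly on this change; the only measured step, a number 10 percentage points higher from compound 2 to compound 3 (within the scatter), altered a different group and stayed within the scatter. The expected step of a number 2 percentage points lower from compound 3 to compound 4 (within the scatter) is therefore small, with no direction beyond the scatter. Compound 4 is expected to give 50%, within 35% to 65%.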

Compound 4, a percentage reported as inhibition, in the whole organism at one dose (the size of the read-out at that dose, not a potency): 54%
Compound 4: the middle estimate sits 4 percentage points below what was measured; the measured number falls inside the stated range.
By their numbers in this assay, from the lowest: compounds 2, 3 and 4 (each within the scatter of the next, the first and the last beyond it).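

Chloro in place of hydrogen, on the aromatic carbon ortho to an isopropoxy group, gives a number 2 percentage points higher from compound 3 to compound 4 (within the scatter) in this assay. Within the data shown here, this is the first look at a substituent on this carbon, and it shows that the chloro group can sit there without a difference that stands out from the scatter. Nothing available explains this outcome.

On these data alone, whether a larger group, such as trifluoromethyl, or an amine would read the same at this carbon remains open. So does whether chloro would give a similar result with phenoxy in place of isopropoxy.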